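Replacing an ether chain with a carbamate on a shared core

The source may hold more compounds than are shown below. What is called first, only, known or untested is meant among the compounds shown, and "the series" means these compounds.

Compound 1 `CC(C)=CCOc1cc(=O)n(CCCO)c2c1CC(CC=C(C)C)C(C)(C)C2` belongs to a small set measured in a functional assay on PANC-1 cells (Homo sapiens) for inhibition, read by MTT assay, with a stated time of 24 h, tested at 10 uM; on this read-out lower numbers stand for less inhibition and higher numbers for more inhibition at the one concentration tested (going by the name of the read-out). In this assay compound 1 gives 7.5%, the second highest of three numbers. Among the measured compounds shown here, compound 2 `CC(C)=CCC1Cc2c(OCCCNS(=O)(=O)c3ccc(C(F)(F)F)cc3)cc(=O)n(CCCO)c2CC1(C)C` gives 0% and compound 3 `CC(C)=CCC1Cc2c(OCCCNS(=O)(=O)c3ccc([N+](=O)[O-])cc3)cc(=O)n(CCCO)c2CC1(C)C` gives 17.3%; both differ from compound 1 at the same oxygen, but by a change for which no single step is defined, so only their values can be compared with that of compound 1, and both lie within the scatter of it. For the measured compounds named here, the one measured step, a number 17.3 percentage points higher from compound 2 to compound 3 (beyond the scatter), concerns a change on the aromatic ring of a sulfonamide and does not bear on the change to compound 4 `CC(C)=CCC1Cc2c(OC(=O)Nc3ccc(F)c(F)c3)cc(=O)n(CCCO)c2CC1(C)C`, which is (3,4-difluorophenyl)carbamoyl in place of 3-methylbut-2-en-1-yl on an oxygen on an aromatic ring. Going by the values given here, no measured step informs this carbamate. Since every number in this set is low and close together, compound 4 is expected to stay in the same region, with an expected step of a number 2.5 percentage points higher from compound 1 to compound 4 (within the scatter), which is not beyond the scatter. The estimate for compound 4 is therefore 10%, with a range from 0% to 30%.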

Compound 4, a percentage reported as inhibition, at one concentration (the size of the read-out at that concentration, not a potency): 0%
Estimate against measurement, compound 4: 10 percentage points above; measured number inside the range.
By their numbers in this assay, from the lowest: compounds 2, 4, 1 and 3 (each within the scatter of the next, the first and the last beyond it).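

Among the compounds shown here, at the oxygen on an aromatic ring, this assay now gives a first direct reading of a carbamate: (3,4-difluorophenyl)carbamoyl in place of 3-methylbut-2-en-1-yl yields a number 7.5 percentage points lower from compound 1 to compound 4 (within the scatter). The earlier compounds shown here could only be set beside compound 1 by their values, whereas this single change shows that swapping an open chain for a larger group with an aromatic ring and a hydrogen-bond donor does not move the read-out beyond the scatter. Nothing available accounts for this outcome.

As far as these compounds go, whether the two fluorines on the ring play any part remains open, and a plain phenylcarbamoyl group would address that. From the compounds shown here alone, it is also open whether a different group on this oxygen, such as an aminoalkyl chain or a chain ending in a carboxylic acid, would lift the number clear of the scatter.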